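The compounds below may be only part of what the source reports. "The series", "measured", "known", "first", "only" and "open" are said of these compounds alone.

Three compounds sharing one core were tested in a functional assay on HT-29 cells (Homo sapiens) for antiproliferative activity, read by MTT assay, with a stated time of 24 h; on this read-out higher numbers stand for weaker inhibition and lower numbers for stronger inhibition. Compound 1 `COc1cc(OC)c(OC)cc1/C=C/C(=O)c1ccc(OC)c2c1OC(C)(C)C=C2` gives a result of > 10000 nM, which is a limit of the assay rather than a number. Compound 2 `COc1ccc(C(=O)/C=C/c2ccc(Br)cc2)c2c1C=CC(C)(C)O2` likewise gives > 10000 nM, again a limit and not a measured number. Compound 3 `COc1ccc(C(=O)/C=C/c2ccc3ccccc3c2)c2c1C=CC(C)(C)O2` gives 4480 nM. Compound 2 thus sits at the limit of > 10000 nM in this assay, at which 2 of the 3 values shown sit, and nothing finer than that is known of it. Compound 4 `COc1ccc(C(=O)/C=C/c2ccc(O)c(Br)c2)c2c1C=CC(C)(C)O2` is the compound still to be tested. It differs from compound 2 in one place: 3-bromo-4-hydroxyphenyl in place of 4-bromophenyl on a double-bonded chain carbon bound to a double-bonded chain carbon. Among the measured compounds shown here, no step between two measured compounds is known here, so there is nothing to calibrate the size of this change against. The expected step from compound 2 to compound 4 in this assay is an at least 1.1-fold lower number from compound 2 to compound 4 (0.04 log units; that floor lies within the scatter), which is judged to be no larger than the usual scatter. Compound 4 is therefore expected to give about 9000 nM, within a range from 2500 nM to 30000 nM, with a fair chance that only a limit is reported again.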

Compound 4, half-maximal inhibitory concentration: > 10000 nM
Compound 4 gave a limit, no number (the forecaster's own chance of this, stated with the estimate: 55%); middle value at least 1.1-fold (0.04 log units) away from the limit.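

Among the compounds shown here, compound 2 and compound 4 both ended at a limit of this assay rather than a number, so no step between them can be read. Both stand at the same place: the limit of > 10000 nM in this assay, at which 3 of the 4 values shown sit.

From the compounds shown here alone, whether 3-bromo-4-hydroxyphenyl in place of 4-bromophenyl changes the inhibition at all remains open.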